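Fluoro to methoxy on the benzothiazole of compound 2

The compounds below may be only part of what the source reports. "The series", "measured", "known", "first", "only" and "open" are said of these compounds alone.

Values measured in an ADME assay on NIH3T3 cells (Mus musculus) for cytotoxicity, read by MTT assay, with a stated time of 24 h (a lower number here means a stronger inhibitor, a higher number a weaker inhibitor), so far
- compound 1 `O=C(CSc1nnc(COc2ccc3c(c2)CCCC3)o1)Nc1nc2ccccc2s1` at 96700 nM
- compound 2 `O=C(CSc1nnc(COc2ccc3c(c2)CCCC3)o1)Nc1nc2ccc(F)cc2s1` at 292000 nM
- compound 3 `O=C(CSc1nnc(COc2ccc3c(c2)CCCC3)o1)Nc1nc2ccc([N+](=O)[O-])cc2s1` at 336000 nM

Compound 2 stands at the upper end of these three numbers, level with compound 3 within the scatter, and well clear of compound 1. The next structure is compound 4 `COc1ccc2nc(NC(=O)CSc3nnc(COc4ccc5c(c4)CCCC5)o3)sc2c1`, with methoxy in place of fluoro on an aromatic carbon and the rest of compound 2 unchanged.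

Within the data shown here, no measured step introduces methoxy, so the evidence is indirect. Two steps start from compound 1 and put a new group on it: a 3.0-fold higher number from compound 1 to compound 2 (0.48 log units; beyond the scatter) for fluoro and a 3.5-fold higher number from compound 1 to compound 3 (0.54 log units; beyond the scatter) for nitro. Both are modest and beyond the scatter. Exchanging one group for the other gives only a 1.2-fold higher number from compound 2 to compound 3 (0.06 log units; within the scatter) and stays within the scatter. Compound 4 may therefore sit with the two substituted compounds, although two examples are thin support, and a drift back toward compound 1 cannot be excluded.

The expected change is a 1.5-fold lower number from compound 2 to compound 4 (0.16 log units; within the scatter), a small move toward a lower number and no clear shift beyond the scatter. For compound 4 the estimated value is 200000 nM, within an expected range of 85000 nM to 420000 nM in this assay once measured.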

Compound 4, half-maximal inhibitory concentration: 94300 nM
Compound 4: the middle estimate sits 2.1-fold (0.33 log units) above what was measured, within the range that was stated.
By their numbers in this assay, from the lowest: compounds 4 and 1 (each within the scatter of the next); then compounds 2 and 3 (each within the scatter of the next).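

In this assay, methoxy on this aromatic carbon parts from the other two substituents, with a 3.1-fold lower number from compound 2 to compound 4 (0.49 log units; beyond the scatter) and a 3.6-fold lower number from compound 3 to compound 4 (0.55 log units; beyond the scatter), both beyond the scatter, while a 1.0-fold lower number from compound 1 to compound 4 (0.01 log units; within the scatter) stays within it. Fluoro and nitro alone allowed the reading that any group placed here gives a higher number than hydrogen, and the 6-methoxy-1,3-benzothiazol-2-yl compound 4 goes against that reading, so the outcome at this position depends on which group enters and not merely on the carbon being substituted. Nothing measured in this set bears on why methoxy falls with hydrogen and apart from fluoro and nitro.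

With only four groups at this one position, the series does not show whether an amine, a hydroxyl or a longer ether such as ethoxy would fall with compound 1 and compound 4 or with compound 2 and compound 3. It also leaves open whether methoxy gives the same result on another carbon of this six-membered aromatic ring, or with changes elsewhere in the shared core.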